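Swapping the Aryl Group for Isopropyl on the Amine Nitrogen

The source may hold more compounds than are shown below. What is called first, only, known or untested is meant among the compounds shown, and "the series" means these compounds.

Of the compounds shown here, three sharing one core have been tested in an ADME assay on HEK293 cells (Homo sapiens) for cytotoxicity, read by MTT assay, with a stated time of 48 h; on this read-out lower numbers stand for stronger inhibition and higher numbers for weaker inhibition. Compound 1 `Cc1ccc(S(=O)(=O)/N=C(/CCNC2=CC(=O)c3ccccc3C2=O)Nc2ccc(Cl)cc2)cc1` gives 65400 nM, compound 2 `Cc1ccc(S(=O)(=O)/N=C(/CCNC2=CC(=O)c3ccccc3C2=O)Nc2ccc(F)cc2)cc1` gives 55100 nM, and compound 3 `Cc1ccc(S(=O)(=O)/N=C(/CCNC2=CC(=O)c3ccccc3C2=O)Nc2cc(F)c(F)c(F)c2)cc1` gives 82600 nM. Compound 3 is set apart from the other two only within the scatter: a 1.3-fold higher number from compound 1 to compound 3 (0.10 log units; within the scatter) and a 1.5-fold higher number from compound 2 to compound 3 (0.18 log units; within the scatter). The change leading to compound 4 `Cc1ccc(S(=O)(=O)/N=C(/CCNC2=CC(=O)c3ccccc3C2=O)NC(C)C)cc1` is isopropyl in place of 3,4,5-trifluorophenyl on an amine nitrogen. Within the data shown here, no measured step bears directly on this: the step of a 1.2-fold lower number from compound 1 to compound 2 (0.07 log units; within the scatter) and the two steps above merely swap one aromatic group for another on that nitrogen, and all stayed within the scatter. Trading the aromatic ring for a short chain is a different kind of change, so there is no ground in this assay to expect a step beyond the scatter. Compound 4 is therefore estimated at 70000 nM, with a range from 30000 nM to 160000 nM. That estimate amounts to an expected step of a 1.2-fold lower number from compound 3 to compound 4 (0.07 log units; within the scatter).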

Compound 4, half-maximal inhibitory concentration: 71600 nM
For compound 4 the middle estimate is 1.0-fold (0.01 log units) below the measured one; low and high end bracket the measured number.
By their numbers in this assay, from the lowest: compounds 2, 1, 4 and 3 (each within the scatter of the next).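

In this assay, the steps of a 1.2-fold lower number from compound 3 to compound 4 (0.06 log units; within the scatter) and a 1.3-fold higher number from compound 2 to compound 4 (0.11 log units; within the scatter) and a 1.1-fold higher number from compound 1 to compound 4 (0.04 log units; within the scatter) all lie within the scatter. On this amine nitrogen, then, the read-out holds not only when one aromatic group replaces another, but also when a group with no ring, isopropyl, with 3 heavy atoms, takes the place of 3,4,5-trifluorophenyl, with 9. Nothing available here explains why the read-out holds. Still open, from the compounds shown here alone, is whether a longer chain, such as n-octyl, would also stay within the scatter. The same question applies to a chain ending in an amine or a carboxylic acid.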